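This account rests on a few compounds, and the source may have more. Where it says the series, first, only, none or still open, it means among the compounds named here.

Three compounds share one core and differ only in the group on an oxygen next to a carbonyl group. Compound 1 `C[C@@H]1CN(C(=O)c2nc(Nc3cc(C4CC4)[nH]n3)c3cc(Cl)ccc3n2)CCN1C(=O)OC(C)(C)C` gives 71.3% in an ADME assay on S9 fraction from liver (Rattus norvegicus), read by LC-MS, with a stated time of 60 min, at 37 degrees C; a lower number here means that less of the compound is left, a higher number that more of the compound is left. Compound 2 `CC(C)OC(=O)N1CCN(C(=O)c2nc(Nc3cc(C4CC4)[nH]n3)c3cc(Cl)ccc3n2)C[C@H]1C` gives 78.6% in this assay, and compound 3 `C[C@@H]1CN(C(=O)c2nc(Nc3cc(C4CC4)[nH]n3)c3cc(Cl)ccc3n2)CCN1C(=O)OCC(Cl)(Cl)Cl` gives 78.9%. Compound 3 has the highest of the three numbers, yet both neighbours sit within the scatter: a number 0.3 percentage points higher from compound 2 to compound 3 (within the scatter) and a number 7.6 percentage points higher from compound 1 to compound 3 (within the scatter); the remaining step, a number 7.3 percentage points higher from compound 1 to compound 2 (within the scatter), is within it as well. Compound 4 `CC(C)C(=O)OCOC(=O)N1CCN(C(=O)c2nc(Nc3cc(C4CC4)[nH]n3)c3cc(Cl)ccc3n2)C[C@H]1C` has not been measured; it differs from compound 3 in this way: (isopropylcarbonyl)oxy in place of trichloromethyl on a saturated chain carbon bound to an oxygen next to a carbonyl group. All three measured steps exchanged groups on this same oxygen and none of them moved the number beyond the scatter, so they point to a small step here too, though the entering group is unlike any of them in bringing a double bond outside aromatic rings and two hydrogen-bond acceptors, which widens the uncertainty. The expected step is a number 13.9 percentage points lower from compound 3 to compound 4 (beyond the scatter). Compound 4 is estimated at 65%, within a range from 35% to 85%.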

Compound 4, percent of the compound remaining: 14%
For compound 4 the middle estimate is 51 percentage points above the measured one; measured number outside the range, below it.
By their numbers in this assay, from the lowest: compound 4; then compounds 1, 2 and 3 (each within the scatter of the next).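

Among the groups shown on this oxygen, the earlier exchanges of tert-butyl, isopropyl and 2,2,2-trichloroethyl left the number in this assay within the scatter, but ((isopropylcarbonyl)oxy)methyl does not (a number 64.9 percentage points lower from compound 3 to compound 4 (beyond the scatter); a number 64.6 percentage points lower from compound 2 to compound 4 (beyond the scatter); a number 57.3 percentage points lower from compound 1 to compound 4 (beyond the scatter)). This position is therefore not indifferent to every change, since one exchange on the same oxygen, with the shared core untouched, separates compound 4 from all three others. Nothing shown here accounts for the drop.

On these data alone, it remains open which part of the entering group goes with the low number. A methoxymethyl group, which has no carbonyl in its chain, or an ((acetyl)oxy)methyl group, with a shorter chain after the carbonyl, could show whether the number stays with compound 4 or returns to that of compound 3.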